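Aryl swap on the ring nitrogen of compound 2

A few compounds are considered here, and "the series" means these few. Any claim that something is new, unique, unknown or untested is made for them only; others in the source may bear on it.

The shared core is a five-membered non-aromatic ring with 2 nitrogen, one ring nitrogen carrying an aryl group. Compound 1 `Cc1cccc(N2N=C(C(C)(C)C)CC2c2ccc(O)cc2)c1` bears 3-methylphenyl there, and in an assay on isolated protein for inhibition of protein kinase C zeta type (Homo sapiens), with a stated time of 4 min, tested at 62.5 uM (a higher number here means more inhibition at the concentration tested (going by the name of the read-out), a lower number less inhibition), compound 1 gives 91.7%. Within the data shown here, compound 2 `CC(C)(C)C1=NN(c2ccc(F)cc2F)C(c2ccc(O)cc2)C1` bears 2,4-difluorophenyl there, and in this assay compound 2 gives 68%, the lower of the two numbers so far; the one measured step, a number 23.7 percentage points lower from compound 1 to compound 2 (beyond the scatter), leads to it from the only other compound.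

Compound 3 `CC(C)(C)C1=NN(c2c(Cl)cccc2Cl)C(c2ccc(O)cc2)C1` is not yet measured. Relative to compound 2 the change is 2,6-dichlorophenyl in place of 2,4-difluorophenyl on an amine nitrogen in a ring. Among the measured compounds shown here, the single measured step concerns the same place on the core but exchanges a different pair of aryl groups, so it bears on the present step only loosely: it shows that swapping the aryl group on this ring nitrogen can move the inhibition by a modest amount, in either direction as far as these data tell. A direct comparison of two dihalogenated phenyl groups is not available. The estimated step is a number 3 percentage points lower from compound 2 to compound 3 (within the scatter). Compound 3 is expected to give 65% in this assay, between 40% and 88%.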

Compound 3, a percentage reported as inhibition, at one concentration (the size of the read-out at that concentration, not a potency): 65.5%
Estimate against measurement, compound 3: 0.5 percentage points below, within the range that was stated.
By their numbers in this assay, from the lowest: compounds 3 and 2 (each within the scatter of the next); then compound 1.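

Notes on the aryl group on the ring nitrogen, with the tert-butyl and 4-hydroxyphenyl groups unchanged: in this assay, exchanging one dihalogenated phenyl group for the other gives a number 2.5 percentage points lower from compound 2 to compound 3 (within the scatter), so this assay does not separate 2,4-difluorophenyl from 2,6-dichlorophenyl, even though both the halogen and the substitution pattern differ. The second new comparison gives a number 26.2 percentage points lower from compound 1 to compound 3 (beyond the scatter), which is in the same direction as a number 23.7 percentage points lower from compound 1 to compound 2 (beyond the scatter), so among these three compounds, both dihalogenated phenyl groups stand lower than 3-methylphenyl, with no compound shown going against that. No supporting data are available to explain why the numbers fall this way.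

From the compounds shown here alone, it remains open whether the higher number with 3-methylphenyl goes with the methyl group itself or simply with the absence of two halogens, and a plain phenyl or a phenyl carrying a single chlorine would separate those readings. Also open, going by these compounds, is how this position responds to a phenyl carrying an amine or a carboxylic acid, and every reading here is a single-concentration inhibition figure rather than a potency.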